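Methoxy in Place of Hydrogen on the Core of Compound 1

A few compounds are considered here, and "the series" means these few. Any claim that something is new, unique, unknown or untested is made for them only; others in the source may bear on it.

Measured so far:
compound 1 `O=c1[nH]nc2n(c1=O)CCN2c1ccccc1` gives 0%
compound 2 `Cc1ccc(N2CCn3c2n[nH]c(=O)c3=O)cc1` gives 14%
compound 3 `Cc1ccc(N2CCN/C2=N\N)cc1` gives 12%

In a functional assay on T47D cells (Homo sapiens) for cytotoxicity, with a stated time of 72 h, tested at 10 ug/mL (on this read-out lower numbers stand for a weaker effect and higher numbers for a stronger effect at the one concentration tested), compound 1 stands lowest of the three numbers. Compound 3 gives 12%, and compound 2 gives 14%, both beyond the scatter above compound 1. Going by the values given here, the only step between measured compounds that changes one place on the aromatic ring is a number 14 percentage points higher from compound 1 to compound 2 (beyond the scatter), a modest rise.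

Compound 4 `COc1ccccc1N1CCn2c1n[nH]c(=O)c2=O` differs from compound 1 by methoxy in place of hydrogen on an aromatic carbon. Among the compounds with values here, no measured pair carries a methoxy, so the methyl step is the only one that bears on this change, and it was modest. A small, uncertain rise from the floor of compound 1 is therefore the most that the data support.

Compound 4 is expected to show a number 6 percentage points higher from compound 1 to compound 4 (within the scatter), a step that may not clear the scatter. Compound 4 is estimated at 6%, with a range from 0% to 20%.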

Compound 4, a percentage reported as inhibition, at one concentration (the size of the read-out at that concentration, not a potency): 1%
The estimate for compound 4 lay 5 percentage points above the measured number, and the stated range covers the measured number.
By their numbers in this assay, from the lowest: compounds 1 and 4 (each within the scatter of the next); then compounds 3 and 2 (each within the scatter of the next).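

In this assay, methoxy on an aromatic carbon ortho to a large group gives a number 1 percentage points higher from compound 1 to compound 4 (within the scatter), so compound 4 cannot be told apart from compound 1. The earlier step, a number 14 percentage points higher from compound 1 to compound 2 (beyond the scatter), involved a methyl, and the two steps differ in both the group and its place on the ring; a substituent on this ring therefore does not always bring a step beyond the scatter. Nothing available gives a reason for this result.

The compounds shown leave open whether the group or its place decides the outcome, as neither methyl nor methoxy appears at both places on the ring. They also leave open what an amine, a carboxylic acid or a longer alkoxy chain would give at this same place in this assay.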